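The source may report more compounds than this note shows. Statements on the series, on what has been measured and on what is new or still open speak of the compounds shown alone.

Working notes on the series, read in a functional assay on HeLa cells (Homo sapiens) for antiproliferative activity, read by MTT assay, with a stated time of 72 h; on this read-out higher numbers stand for weaker inhibition and lower numbers for stronger inhibition. Compound 1 `O=C1NC(O)(/C=C\n2cc(I)c3c(Cl)ncnc32)C(OCc2ccccc2)=C1OCc1ccccc1` gives only a limit, > 250000 nM, and not a number. Compound 2 `O=C1NC(O)(CCn2cnc3cncc(Br)c32)C(OCc2ccccc2)=C1OCc1ccccc1` gives 77000 nM and compound 3 `COc1nc(OC)c2c(ccn2CCC2(O)NC(=O)C(OCc3ccccc3)=C2OCc2ccccc2)n1` gives 92000 nM. These two values lie within the scatter of each other, so compound 2 stands level with compound 3 among the numbers available.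

Compound 4 `Nc1nc(F)c(Cl)c2c1ncn2CCC1(O)NC(=O)C(OCc2ccccc2)=C1OCc1ccccc1` has not yet been measured. It differs from compound 2 by a group of 12 heavy atoms (6 carbon, 4 nitrogen, 1 fluorine, 1 chlorine; one five-membered aromatic ring with 2 hetero atoms, one six-membered aromatic ring with 1 hetero atom) in place of a group of 10 heavy atoms (6 carbon, 3 nitrogen, 1 bromine; one five-membered aromatic ring with 2 hetero atoms, one six-membered aromatic ring with 1 hetero atom), on a saturated chain carbon, two bonds along the chain from a saturated ring carbon, and the change sits on a saturated chain carbon, two bonds along the chain from a saturated ring carbon. Both groups keep one five-membered aromatic ring with 2 hetero atoms and one six-membered aromatic ring with 1 hetero atom. Among the measured compounds shown here, no measured pair differs in one place, so the data give no direct size for such a step. The expectation therefore rests on compound 2 at 77000 nM and compound 3 at 92000 nM, and no change beyond the scatter is expected. The expected step is a 1.2-fold lower number from compound 2 to compound 4 (0.07 log units; within the scatter).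

The estimated value for compound 4 is 65000 nM, with an expected range from 20000 nM to 200000 nM.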

Compound 4, half-maximal inhibitory concentration: 39000 nM
The estimate for compound 4 lay 1.7-fold (0.22 log units) above the measured number; the range from low to high includes it.
By their numbers in this assay, from the lowest: compounds 4, 2 and 3 (each within the scatter of the next, the first and the last beyond it). At a limit, above all of these: compound 1.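

Among the compounds shown here, the step of a 2.0-fold lower number from compound 2 to compound 4 (0.30 log units; within the scatter) in this assay is the only comparison that differs in one place, and it gives the first direct reading at this saturated chain carbon. Exchanging the bromine-bearing group for the group bearing fluorine and chlorine, which also adds a hydrogen-bond donor, moves the number no further than the scatter, so the two groups cannot be told apart on this read-out. Compound 1 remains a limit and not a number: the limit of > 250000 nM in this assay, at which 1 of the 4 values shown sits.

Because the exchange alters the halogens, the nitrogen count and the donor count together, the compounds shown do not separate the contribution of each. Also open, as far as these compounds go, is how a longer chain, or a carboxylic acid on the same ring pair, would read at this place.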